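The compounds below may be only part of what the source reports. "The series", "measured", "known", "first", "only" and "open" are said of these compounds alone.

Measured compounds:
- Compound 1 `C=C(Br)C(=O)Nc1ccc(/C=C2\SC(=O)N(CC)C2=O)cc1` gives 500 nM in a functional assay on L1210 cells (Mus musculus) for cytotoxicity, read by cell counting, with a stated time of 2 days; a higher number here means a weaker inhibitor, a lower number a stronger inhibitor
- Compound 2 `Nc1cccc(/C=C2\SC(=O)N(Cc3ccc(F)cc3)C2=O)c1` gives 142000 nM in this assay

Of the two measured compounds, compound 2 has the highest number; the nearest is compound 1, whose number is lower by a margin beyond the scatter, so compound 2 is the weaker inhibitor of the pair. No single-point comparison between these two is available, since they differ in several places at once.

Compound 3 `Nc1cccc(/C=C2\SC(=O)N(Cc3ccccc3)C2=O)c1` is the untested neighbour of compound 2. The change is hydrogen in place of fluoro on an aromatic carbon, with the fluoro sitting para to a large group; seen one bond further out, a 4-fluorophenyl becomes a phenyl. A change this small, far from the shared core, is expected to move the number little, in no clear direction and not beyond the scatter. The expected step from compound 2 to compound 3 in this assay is therefore a 1.1-fold higher number from compound 2 to compound 3 (0.02 log units; within the scatter). Compound 3 is estimated at 150000 nM, within a range of 40000 nM to 500000 nM.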

Compound 3, half-maximal inhibitory concentration: 233000 nM
Estimate against measurement, compound 3: 1.6-fold (0.19 log units) below; low and high end bracket the measured number.
By their numbers in this assay, from the lowest: compound 1; then compounds 2 and 3 (each within the scatter of the next).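

Going from a 4-fluorophenyl to a phenyl gives a 1.6-fold higher number from compound 2 to compound 3 (0.22 log units; within the scatter) in this assay, the first comparison here in which only one place differs. At this position, para to a large group, replacing fluoro with hydrogen therefore has no effect that can be told apart from the ordinary variation between repeated measurements. Nothing measured here offers an explanation for this result.

As far as these compounds go, whether a chlorine atom, a methoxy group or a carboxylic acid at the same position would shift the number beyond that variation remains open. Also open, from the compounds shown here alone, is how replacing the amine shared by compound 2 and compound 3 with an amide would alter the number when every other part of the structure stays the same.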